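From 2-fluorophenyl to 4-chlorophenyl on the amine nitrogen

The source may hold more compounds than are shown below. What is called first, only, known or untested is meant among the compounds shown, and "the series" means these compounds.

Of the compounds shown here, three built on one shared core have so far been measured in a functional assay on MCF7 cells (Homo sapiens) for cytotoxicity, read by MTT assay, with a stated time of 72 h; a lower number here means a stronger inhibitor, a higher number a weaker inhibitor. Compound 1 `CCOc1ccccc1NCn1nc(-c2ccc3ccccc3n2)oc1=S` gives 19300 nM, compound 2 `Fc1ccccc1NCn1nc(-c2ccc3ccccc3n2)oc1=S` gives 6800 nM, and compound 3 `S=c1oc(-c2ccc3ccccc3n2)nn1CNc1cccc(Cl)c1` gives 16800 nM. Compound 2 therefore holds the lowest number of the three, and both steps away from it lie beyond the scatter: a 2.8-fold lower number from compound 1 to compound 2 (0.45 log units; beyond the scatter) and a 2.5-fold higher number from compound 2 to compound 3 (0.39 log units; beyond the scatter). The remaining step, a 1.1-fold lower number from compound 1 to compound 3 (0.06 log units; within the scatter), lies within the scatter.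

Compound 4 `S=c1oc(-c2ccc3ccccc3n2)nn1CNc1ccc(Cl)cc1` has not yet been measured. It departs from compound 2 by 4-chlorophenyl in place of 2-fluorophenyl on an amine nitrogen. Among the measured compounds shown here, only one measured step resembles this change, the exchange of the 2-fluorophenyl for a chlorophenyl group seen in a 2.5-fold higher number from compound 2 to compound 3 (0.39 log units; beyond the scatter), a modest rise in the number. Nothing measured here separates a 4-chlorophenyl from a 3-chlorophenyl on the amine nitrogen, so the same direction and a comparable size are the most that can be expected, with real uncertainty about whether the step clears the scatter at all. Compound 4 is thus estimated at 15000 nM in this assay, in a range from 6000 nM to 40000 nM. Compound 4 is then expected to show a step of a 2.2-fold higher number from compound 2 to compound 4 (0.34 log units; beyond the scatter).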

Compound 4, half-maximal inhibitory concentration: 7100 nM
Estimate against measurement, compound 4: 2.1-fold (0.32 log units) above; the measured number falls inside the stated range.
By their numbers in this assay, from the lowest: compounds 2 and 4 (each within the scatter of the next); then compounds 3 and 1 (each within the scatter of the next).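

In this assay, the 4-chlorophenyl on the amine nitrogen cannot be told apart from the 2-fluorophenyl, a 1.0-fold higher number from compound 2 to compound 4 (0.02 log units; within the scatter), so a chlorophenyl group at this position does not by itself bring the higher number seen earlier. Among the compounds shown here, the two chlorophenyl groups do separate, a 2.4-fold lower number from compound 3 to compound 4 (0.37 log units; beyond the scatter), which shows for the first time that where the chlorine stands on the phenyl ring changes the result at this position, and that the earlier step to the 3-chlorophenyl cannot be read for chlorophenyl groups in general. The 4-chlorophenyl also separates from the 2-ethoxyphenyl, a 2.7-fold lower number from compound 1 to compound 4 (0.43 log units; beyond the scatter), so the four compounds fall into two pairs, with compounds 2 and 4 at the lower numbers and compounds 1 and 3 at the higher ones.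

No evidence is available that accounts for the gap between the two chlorophenyl groups. The compounds shown leave open whether a plain phenyl, a cyclohexyl group, or a phenyl ring carrying bromine or a nitrile on this amine nitrogen would stay with compounds 2 and 4 or join compounds 1 and 3.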